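A Chloro Substituent on a Series Sitting at the Assay Limit

A few compounds are considered here, and "the series" means these few. Any claim that something is new, unique, unknown or untested is made for them only; others in the source may bear on it.

Compound 1 `O=C1OCC[C@@H]1NC(=S)SCCOc1ccccc1`: > 64000 nM
Compound 2 `O=C1OCC[C@@H]1NC(=S)SCCOc1ccccc1[N+](=O)[O-]`: > 64000 nM
Compound 3 `CCOc1ccccc1OCCSC(=S)N[C@H]1CCOC1=O`: > 64000 nM

In a functional assay on MCF7 cells (Homo sapiens) for antiproliferative activity, read by MTT assay, with a stated time of 72 h (a higher number here means a weaker inhibitor, a lower number a stronger inhibitor), compound 1 gives > 64000 nM, which is a limit of the assay and not a number. Compound 2 likewise gives > 64000 nM, again a limit. Compound 3 gives > 64000 nM, also a limit. Because all three values sit at the limit of > 64000 nM in this assay, at which 3 of the 3 values shown sit, the steps a step that the two limits leave unreadable from compound 1 to compound 2, a step that the two limits leave unreadable from compound 1 to compound 3 and a step that the two limits leave unreadable from compound 2 to compound 3 cannot be read: neither their size nor their direction is known.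

Compound 4 `O=C1OCC[C@@H]1NC(=S)SCCOc1ccc(Cl)cc1` differs from compound 1 by chloro in place of hydrogen on an aromatic carbon. The measured steps that bear on this change are those from compound 1, a substitution on the same aromatic ring with a different group, and each of them is unreadable. With nothing to show that any substituent on this ring moves the read-out away from the limit, the expectation for compound 4 in this assay is no step beyond the scatter, meaning a value that again lands at the limit; the estimated step that the limit leaves unreadable from compound 1 to compound 4 is therefore close to zero. The estimate for compound 4 is 100000 nM, with a range from 30000 nM to 400000 nM.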

Compound 4, half-maximal inhibitory concentration: 50500 nM
Compound 4: middle estimate off by 2.0-fold (0.30 log units), on the high side; low and high end bracket the measured number.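

In this assay, compound 4 is the first compound shown to give a measured number rather than a limit, and it carries its chloro on an aromatic carbon, para to a large group. Putting chloro in place of hydrogen there gives an at least 1.2-fold lower number from compound 1 to compound 4 (0.10 log units; that floor lies within the scatter), so this change is compatible with a real gain, but the printed floor alone does not establish one. The steps among compounds 1, 2 and 3 cannot be read, and this new step has only a floor, because most of the series sits at one assay limit: the limit of > 64000 nM in this assay, at which 3 of the 4 values shown sit.

On these data alone, the true distance between compound 1 and compound 4 stays open, as the value of compound 1 marks only where the readable range ends, not where the compound itself lies. Also open, as far as these compounds go, is whether bromo, methyl or an amine at this same place would likewise give a measured number, or whether this result belongs to chloro alone.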